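Replacing methylsulfanyl with cyano on the shared core

The source may hold more compounds than are shown below. What is called first, only, known or untested is meant among the compounds shown, and "the series" means these compounds.

Measured so far in an ADME assay on microsomes from liver (Rattus norvegicus) for metabolic stability (on this read-out higher numbers stand for fast clearance and lower numbers for slow clearance), are three compounds:
- compound 1 `CNc1nc(NC2(C#N)CCCCC2)nc(-n2cncn2)n1` gives 52 mL/min/kg
- compound 2 `CNc1nc(NC2(C#N)CCCCC2)nc(OC)n1` gives 196 mL/min/kg
- compound 3 `CNc1nc(NC2(C#N)CCCCC2)nc(SC)n1` gives 579 mL/min/kg

Still unmeasured is compound 4 `CNc1nc(C#N)nc(NC2(C#N)CCCCC2)n1` in the same test.

Compound 3 stands highest of the three, clearly apart from the other two. Compound 4 carries cyano in place of methylsulfanyl on an aromatic carbon on the same core. All three measured steps changed this same place. There was a 3.8-fold higher number from compound 1 to compound 2 (0.58 log units; beyond the scatter) and also a 3.0-fold higher number from compound 2 to compound 3 (0.47 log units; beyond the scatter) as a modest step, while an 11-fold higher number from compound 1 to compound 3 (1.05 log units; beyond the scatter) was large. For the measured compounds named here, no measured compound carries cyano, so this is uncertain, but a modest to large fall is expected in this assay here. The expected change is a 6.4-fold lower number from compound 3 to compound 4 (0.81 log units; beyond the scatter) and it should lie beyond the scatter. For compound 4 the estimated value is 90 mL/min/kg with an expected range from 35 mL/min/kg to 230 mL/min/kg in this test.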

Compound 4, clearance: 122 mL/min/kg
Compound 4: middle estimate off by 1.4-fold (0.13 log units), on the low side, within the range that was stated.
By their numbers in this assay, from the lowest: compound 1; then compounds 4 and 2 (each within the scatter of the next); then compound 3.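

Swapping methylsulfanyl for cyano, which has the same count of heavy atoms, gives a 4.7-fold lower number from compound 3 to compound 4 (0.68 log units; beyond the scatter) in this assay, so that count alone does not set the clearance at this place. Cyano and methoxy cannot be told apart here, with a 1.6-fold lower number from compound 2 to compound 4 (0.21 log units; within the scatter) as the step between them. The 1H-1,2,4-triazol-1-yl group still gives the lowest number of the four, and a 2.3-fold higher number from compound 1 to compound 4 (0.37 log units; beyond the scatter) is the step that separates it from cyano. Whether an amine or a carboxylic acid at this place would fall nearer compound 1 or compound 3 remains open, and nothing shown gives a reason for these differences.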